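A Chloro-for-Fluoro Swap at the Edge of Detection

The source may hold more compounds than are shown below. What is called first, only, known or untested is meant among the compounds shown, and "the series" means these compounds.

Compound 3 `N#CC1=C(N)Oc2c(c3nc4ccccc4nc3c3ccccc23)C12C(=O)N(Cc1cnnn1-c1ccc(F)c(Cl)c1)c1ccccc12` belongs to a trio of compounds that share one core and differ only in the aryl group on the aromatic nitrogen. In a functional assay on MCF7 cells (Homo sapiens) for antiproliferative activity, read by MTT assay, with a stated time of 48 h (on this read-out lower numbers stand for stronger inhibition and higher numbers for weaker inhibition), compound 3 gives > 50000 nM, which is a limit of the assay rather than a number. Compound 1 `N#CC1=C(N)Oc2c(c3nc4ccccc4nc3c3ccccc23)C12C(=O)N(Cc1cnnn1-c1ccc(Br)cc1)c1ccccc12`, carrying a 4-bromophenyl group, gives 36600 nM in this assay. Compound 2 `CCOc1ccccc1-n1nncc1CN1C(=O)C2(C(C#N)=C(N)Oc3c2c2nc4ccccc4nc2c2ccccc32)c2ccccc21`, with a 2-ethoxyphenyl group, gives > 50000 nM in this assay, again a limit. The step of an at least 1.3-fold higher number from compound 1 to compound 3 (0.13 log units; that floor lies within the scatter) and the step of an at least 1.3-fold higher number from compound 1 to compound 2 (0.13 log units; that floor lies within the scatter) both run into (the limit of > 50000 nM in this assay, at which 2 of the 3 values shown sit), and the step that the two limits leave unreadable from compound 2 to compound 3 likewise sits within the limit of > 50000 nM in this assay, at which 2 of the 3 values shown sit, and cannot be sized. Compound 4 `N#CC1=C(N)Oc2c(c3nc4ccccc4nc3c3ccccc23)C12C(=O)N(Cc1cnnn1-c1ccc(Cl)c(Cl)c1)c1ccccc12` differs from compound 3 by chloro in place of fluoro on an aromatic carbon. Among the measured compounds shown here, the only change of halogen pattern measured here, an at least 1.3-fold higher number from compound 1 to compound 3 (0.13 log units; that floor lies within the scatter), ended at the limit, so the closest guide to the new step offers a floor but no true size. Since compound 3 already sits at the limit, compound 4 is expected to remain near or beyond it, with an estimated step that the limit leaves unreadable from compound 3 to compound 4 in this assay that is not expected to exceed the scatter. Compound 4 is therefore estimated at 60000 nM, between 25000 nM and 150000 nM.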

Compound 4, half-maximal inhibitory concentration: > 50000 nM
Compound 4: no number, only a limit (the forecaster's own chance of this, stated with the estimate: 70%); the middle value does not contradict the limit.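

Compound 4 also stands only as a limit in this assay, so chloro in place of fluoro on this aromatic carbon, ortho to a chloro group and para to a large group, yields no number. Among the compounds shown here, the only step that can be read is an at least 1.3-fold higher number from compound 1 to compound 4 (0.13 log units; that floor lies within the scatter), and the steps among compound 2, compound 3 and compound 4 cannot be read. With 3,4-dichlorophenyl added, the limit now takes in a further aryl group and most of this small set: the limit of > 50000 nM in this assay, at which 3 of the 4 values shown sit.

For the compounds shown here, compound 1, at 36600 nM, remains the only compound here with a true number, so the size of any difference between 3-chloro-4-fluorophenyl and 3,4-dichlorophenyl stays open. Also open, on these data alone, is whether an amine, a carboxylic acid or a longer chain such as propoxy on this phenyl ring would give a value that can be read in this assay.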